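Benzyl substituent variation on the shared core in MCF7

The source may hold more compounds than are shown below. What is called first, only, known or untested is meant among the compounds shown, and "the series" means these compounds.

Compound 3 `Cc1cc(Nc2ccn(Cc3nc(C)c4ccccc4n3)n2)n2nc(SCc3ccc(Br)cc3)nc2n1` gives 1430 nM in a functional assay on MCF7 cells (Homo sapiens) for inhibition, read by MTT assay, with a stated time of 72 h (on this read-out higher numbers stand for weaker inhibition and lower numbers for stronger inhibition), the lowest of the two numbers measured; its nearest neighbour is compound 1 `Cc1cc(Nc2ccn(Cc3cccc4ccccc34)n2)n2nc(SCc3ccc(Br)cc3)nc2n1`, which in this assay gives 4310 nM. Compound 2 `Cc1cc(Nc2cc(-c3ccccc3)[nH]n2)n2ncnc2n1` reaches only a limit in this assay, > 50000 nM, so it is not a number and does not enter the comparison (the limit of > 50000 nM in this assay, at which 1 of the 3 values shown sits).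

Compound 4 `Cc1ccc(Cn2ccc(Nc3cc(C)nc4nc(SCc5ccc(Br)cc5)nn34)n2)cc1` differs from compound 3 in one place: 4-methylphenyl in place of 4-methylquinazolin-2-yl on a saturated chain carbon bound to an aromatic nitrogen. Among the measured compounds shown here, the one measured step in the same place, a 3.0-fold lower number from compound 1 to compound 3 (0.48 log units; beyond the scatter), shows that exchanging the aromatic group on the saturated chain carbon bound to an aromatic nitrogen moves this assay by a modest but real amount. The group now entering is the smallest of the three and carries none of the acceptor atoms that came in with the 4-methylquinazolin-2-yl group. A step back toward the higher number of compound 1 is therefore expected, modest in size, with a 2.1-fold higher number from compound 3 to compound 4 (0.32 log units; beyond the scatter) the expected change. Compound 4 is estimated at 3000 nM in this assay, within 1200 nM to 9000 nM.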

Compound 4, half-maximal inhibitory concentration: 11300 nM
Compound 4: the middle estimate sits 3.8-fold (0.58 log units) below what was measured; the measured number lies above the stated range.
By their numbers in this assay, from the lowest: compound 3; then compound 1; then compound 4. At a limit, above all of these: compound 2.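

The change to 4-methylphenyl gives a 7.9-fold higher number from compound 3 to compound 4 (0.90 log units; beyond the scatter), a larger step at this place, on a saturated chain carbon bound to an aromatic nitrogen, than the earlier 3.0-fold lower number from compound 1 to compound 3 (0.48 log units; beyond the scatter). It also carries the series past compound 1, with a 2.6-fold higher number from compound 1 to compound 4 (0.42 log units; beyond the scatter), so the 4-methylphenyl group, rather than naphthalen-1-yl, now marks the high end of the three numbers at this place. Across compound 1, compound 3 and compound 4, the two groups with two aromatic rings give lower numbers than the group with one, and none of the three goes against this.

Nothing shown accounts for this order. As far as these compounds go, how a pyridin-2-yl group would read at this place stays open, and it would separate the number of rings from the presence of ring nitrogen.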